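The compounds below may be only part of what the source reports. "The series", "measured", "known", "first", "only" and "open" are said of these compounds alone.

Measured compounds, in a functional assay on HCC827 cells (Homo sapiens) for inhibition, read by MTT assay, with a stated time of 48 h, tested at 10 uM; a lower number here means less inhibition, a higher number more inhibition at the concentration tested (going by the name of the read-out):

Compound 1, `COc1ccc(F)cc1Nc1cc(NC(=O)Nc2c(Cl)cccc2Cl)ncn1`, gives 78%.
Compound 2, `COc1cc(NC(=O)Nc2cc(Nc3cccc(C(C)(C)C)c3)ncn2)cc(OC)c1`, gives 48.7%.
Compound 3, `COc1cc(NC(=O)Nc2cc(Nc3cc(F)ccc3OC)ncn2)cc(OC)c1`, gives 59%.

Compounds 2 and 3 differ in the group on the nitrogen on the aromatic ring: 3-(tert-butyl)phenyl in place of 5-fluoro-2-methoxyphenyl on a nitrogen on an aromatic ring. In this assay that change runs a number 10.3 percentage points higher from compound 2 to compound 3 (beyond the scatter), so compound 2 stands lowest of the three measured numbers. Compounds 3 and 1 differ instead on the amide-type nitrogen: 2,6-dichlorophenyl in place of 3,5-dimethoxyphenyl on an amide-type nitrogen. That step is a number 19 percentage points higher from compound 3 to compound 1 (beyond the scatter), the larger of the two measured steps.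

Compound 4, `CC(C)(C)c1cccc(Nc2cc(NC(=O)Nc3c(Cl)cccc3Cl)ncn2)c1`, has not yet been measured in this assay. It carries the same change relative to compound 2: 2,6-dichlorophenyl in place of 3,5-dimethoxyphenyl on an amide-type nitrogen. The place is the same as in the step from compound 3 to compound 1, on an amide-type nitrogen whose other neighbours are a carbonyl carbon, so this is the same change seen once already. On that basis a step of a number 17.3 percentage points higher from compound 2 to compound 4 (beyond the scatter) is expected from compound 2 to compound 4, resting on compound 1 having shown a number 19 percentage points higher from compound 3 to compound 1 (beyond the scatter). Compound 4 is therefore estimated at 66%, between 50% and 82%.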

Compound 4, a percentage reported as inhibition, at one concentration (the size of the read-out at that concentration, not a potency): 37.3%
Estimate against measurement, compound 4: 28.7 percentage points above; measured number outside the range, below it.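

In this assay the change from 3,5-dimethoxyphenyl to 2,6-dichlorophenyl on the amide-type nitrogen did not carry from one core to the other, since this time it gave a number 11.4 percentage points lower from compound 2 to compound 4 (beyond the scatter), opposite in direction to the earlier step: the same change on two cores in this assay, a number 19 percentage points higher (beyond the scatter) from compound 3 to compound 1 and a number 11.4 percentage points lower (beyond the scatter) from compound 2 to compound 4, 30.4 percentage points apart, beyond the scatter of two such steps

For these two pairs, then, the outcome of the change depends on the group on the nitrogen on the aromatic ring, and a gain seen with 5-fluoro-2-methoxyphenyl there cannot be assumed with 3-(tert-butyl)phenyl. Two pairs do not show why the direction reverses, nor do they give a rule for the whole series.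

The compounds shown leave open which part of the group on that nitrogen decides the direction, something an unsubstituted phenyl, a 2-methoxyphenyl or a 3-fluorophenyl there could help to separate. They also leave open whether the reversal holds at other concentrations, as every number here comes from a single one.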